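Changing the Furan-2-yl End of Compound 2

A few compounds are considered here, and "the series" means these few. Any claim that something is new, unique, unknown or untested is made for them only; others in the source may bear on it.

Three compounds sharing one core were measured in an ADME assay for permeability, using PAMPA, with a stated time of 30 min, at pH 7.4; a higher number here means that the compound crosses the layer faster, a lower number that the compound crosses the layer more slowly. Compound 1 `c1ccc(CCc2ccc3c(NCCCNCc4ccco4)ccnc3c2)cc1` gives 23 10^-6 cm/s. Compound 2 `Clc1ccc(Oc2ccc3c(NCCCNCc4ccco4)ccnc3c2)cc1` gives 317 10^-6 cm/s, and compound 3 `COc1ccc(Oc2ccc3c(NCCCNCc4ccco4)ccnc3c2)cc1` gives 317 10^-6 cm/s. Compound 2 thus stands level with compound 3 at the top of the three, with no change at the digits printed from compound 2 to compound 3 (within the scatter), while a 14-fold higher number from compound 1 to compound 2 (1.14 log units; beyond the scatter) and a 14-fold higher number from compound 1 to compound 3 (1.14 log units; beyond the scatter) set both apart from compound 1. Going by the values given here, compound 4 `COc1ccc(F)cc1CNCCCNc1ccnc2cc(Oc3ccc(Cl)cc3)ccc12` differs from compound 2 at a place that no measured step touches: 5-fluoro-2-methoxyphenyl in place of furan-2-yl on a saturated chain carbon bound to an amine nitrogen. Among the compounds with values here, all three measured steps alter the group on the aromatic carbon of the core instead, and the one exchange there between two substituted phenoxy groups stayed within the scatter. Within the data shown here, with no direct precedent, compound 4 is expected to stay close to compound 2, a 1.1-fold lower number from compound 2 to compound 4 (0.05 log units; within the scatter). Compound 4 is estimated at 280 10^-6 cm/s, between 140 10^-6 cm/s and 560 10^-6 cm/s.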

Compound 4, apparent permeability: 317 10^-6 cm/s
Compound 4: the middle estimate sits 1.1-fold (0.05 log units) below what was measured; measured number inside the range.
By their numbers in this assay, from the lowest: compound 1; then compounds 2, 3 and 4 (each within the scatter of the next).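

The earlier steps shown here all changed the group on the aromatic carbon of the core, whereas this one changes the other end of the molecule, and in this assay it gives no change at the digits printed from compound 2 to compound 4 (within the scatter). At this place on a saturated chain carbon bound to an amine nitrogen, the larger 5-fluoro-2-methoxyphenyl, a six-membered ring of carbon only, can therefore replace the five-membered furan-2-yl, at least with 4-chlorophenoxy on the core. Nothing available explains this result. From the compounds shown here alone, whether a cyclohexyl group or a carboxylic acid at this place would keep the number level remains open, as does whether the same exchange would read alike with the phenethyl group of compound 1.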